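Amide to Free Acid: Expected Cytotoxicity of Compound 4

The source may report more compounds than this note shows. Statements on the series, on what has been measured and on what is new or still open speak of the compounds shown alone.

Compound 1 `C=CC1=C(C(=O)NCc2ccccc2)C(c2ccc(OC)c(OC)c2)OC1` was examined in a functional assay on A549 cells (Homo sapiens) for cytotoxicity, read by MTT assay, with a stated time of 24 h; a lower number here means a stronger inhibitor, a higher number a weaker inhibitor. In this assay compound 1 gives > 100000 nM, which is a limit of the assay and not a number. Compound 2 `C=CC1=C(C(=O)NCCCCC)C(c2ccc(Cl)c(Cl)c2)OC1` in this assay gives > 100000 nM, again a limit. Compound 3 `C=CC1=C(C(=O)NC(C)(C)C)C(c2ccc(OC)cc2)OC1` in this assay gives > 100000 nM, also a limit. Among the measured compounds shown here, compound 1 therefore stands where every measured compound stands, since all three sit at the limit of > 100000 nM in this assay, at which 3 of the 3 values shown sit; no compound is separated from another, and no step between measured compounds can be described.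

Compound 4 `C=CC1=C(C(=O)O)C(c2ccc(OC)c(OC)c2)OC1` differs from compound 1 by hydroxy in place of benzylamino on a carbonyl carbon. For the measured compounds named here, no measured pair shows a change of this kind, so the data give no direction for it. The step from compound 1 to compound 4 in this assay is expected to be none beyond the scatter, a step that the limit leaves unreadable from compound 1 to compound 4. For compound 4 in this assay the estimate is 200000 nM, with a range from 50000 nM to 1000000 nM, most likely reported again only as a limit.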

Compound 4, half-maximal inhibitory concentration: > 100000 nM
Compound 4 was reported as a limit; the forecaster's own chance of this, stated with the estimate: 90%; the middle value does not contradict the limit.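

In this assay compound 4 gives > 100000 nM, which is a limit of the assay and not a number. Compound 1 also sits at a limit, so no step between compound 1 and compound 4 can be read: the limit of > 100000 nM in this assay, at which 4 of the 4 values shown sit.

The compounds shown leave open whether hydroxy in place of benzylamino on a carbonyl carbon alters cytotoxicity at all.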